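Working notes: compound 2 to compound 3

The compounds below may be only part of what the source reports. "The series", "measured", "known", "first", "only" and "open" are said of these compounds alone.

Measured so far in an ADME assay on MRC5 cells (Homo sapiens) for cytotoxicity, read by resazurin assay, with a stated time of 7 days; on this read-out higher numbers stand for lower toxicity in this test and lower numbers for higher toxicity in this test
- compound 1 `OC(c1ccccc1)c1c(C(F)(F)F)nc2ccc(Br)cc2c1Br` gives 1510 nM
- compound 2 `COc1ccccc1NC(=S)Nc1ccc2nc(Oc3ccc(F)cc3C(C)O)c(Cc3ccccc3)cc2c1` gives 16000 nM

Of these two compounds, compound 2 has the higher number, and its gap to compound 1 lies beyond the scatter. The two differ in more than one place, so their gap says nothing direct about the next change.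

Compound 3 `COc1ccccc1NC(=O)Nc1ccc2nc(Oc3ccc(F)cc3C(C)O)c(Cc3ccccc3)cc2c1` differs from compound 2 in a single place, with a group of 11 heavy atoms (8 carbon, 1 nitrogen, 2 oxygen; one six-membered aromatic ring of carbon only) in place of a group of 11 heavy atoms (8 carbon, 1 nitrogen, 1 oxygen, 1 sulfur; one six-membered aromatic ring of carbon only), on a nitrogen on an aromatic ring as the counted change. The group that enters is (2-methoxyphenyl)carbamoyl, on the same nitrogen on an aromatic ring. Within the data shown here, no measured pair shows this change, so no step beyond the scatter is expected in this assay and no firm direction can be given. The estimated change is a 1.1-fold higher number from compound 2 to compound 3 (0.05 log units; within the scatter) and is small. For compound 3 the expected value is 18000 nM (estimated range 6500 nM to 55000 nM).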

Compound 3, half-maximal cytotoxic concentration in the MRC5 assay: 6210 nM
Compound 3: the middle estimate sits 2.9-fold (0.46 log units) above what was measured; measured number outside the range, below it.
By their numbers in the MRC5 assay, from the lowest: compound 1; then compound 3; then compound 2.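

Notes on the series: at the nitrogen on an aromatic ring, the entry of (2-methoxyphenyl)carbamoyl for the sulfur-bearing group is the first single-place change available, and in the MRC5 assay it gives a 2.6-fold lower number from compound 2 to compound 3 (0.41 log units; beyond the scatter), so the lower number points to higher toxicity in this test. In a physicochemical assay for lipophilicity (on this read-out lower numbers stand for lower lipophilicity and higher numbers for higher lipophilicity), compound 2 gives 7.86 and compound 3 gives 6.72. In the physicochemical assay the same change gives a number 1.14 log units lower from compound 2 to compound 3 (beyond the scatter). In this one pair, lower lipophilicity therefore comes with higher toxicity in this test, not lower: the measured partition coefficient of compound 2, 7.86, and of compound 3, 6.72, a number 1.14 log units lower (beyond the scatter)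

A single pair cannot show whether the shift in the MRC5 assay follows lipophilicity or the exchange of sulfur for oxygen itself. On these data alone, how a sulfonyl group or a guanidine at this same nitrogen would fall on both read-outs remains open.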